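The source may hold more compounds than are shown below. What is called first, only, known or untested is meant among the compounds shown, and "the series" means these compounds.

Compound 1 `O=C(CN1CCN(c2ccc(F)cc2)CC1)Nc1nc2c(s1)CCCC2` gives 4000 nM in an assay on isolated protein for inhibition of long-chain fatty acid transport protein 1 (Mus musculus), read by scintillation counting, with a stated time of 20 min; on this read-out lower numbers stand for stronger inhibition and higher numbers for weaker inhibition.
Compound 2 `O=C(CN1CCN(c2ccc(F)cc2)CC1)Nc1nc2c(o1)CCCC2` gives 5400 nM in this assay.

Compound 1 has the lowest number of the two, but compound 2 lies within the scatter of it, so the two cannot be set apart. Compound 3 `O=C(CN1CCN(c2cccnc2)CC1)Nc1nc2c(s1)CCCC2` is not yet measured. It differs from compound 1 in one place: pyridin-3-yl in place of 4-fluorophenyl on an amine nitrogen in a ring. Among the compounds with values here, no measured pair shows a step of this kind here, so the size rests on expectation alone. A small step toward a higher number, of the order of the scatter, is expected: a 1.6-fold higher number from compound 1 to compound 3 (0.21 log units; within the scatter). For compound 3 the estimated value is 6500 nM, within a range from 2200 nM to 20000 nM.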

Compound 3, half-maximal inhibitory concentration: > 10000 nM
Compound 3 gave a limit, no number (the forecaster's own chance of this, stated with the estimate: 10%); middle value at least 1.5-fold (0.18 log units) from the limit.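

Both earlier compounds carry 4-fluorophenyl on this amine nitrogen in a ring, so only compound 3 tests a change at this position. Pyridin-3-yl in place of 4-fluorophenyl gives an at least 2.5-fold higher number from compound 1 to compound 3 (0.39 log units; beyond the scatter) in this assay, which shows that inhibition here is sensitive to this swap. The value of compound 3 is a limit and not a number, so this step sets only a lower bound on the size: the limit of > 10000 nM in this assay, at which 1 of the 3 values shown sits.

A plain phenyl at this position would help show whether the loss goes with the fluorine leaving or the pyridine nitrogen entering. As far as these compounds go, that question stays open.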